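A Chlorine Added Where Both Measured Compounds Sit at the Limit

This account rests on a few compounds, and the source may have more. Where it says the series, first, only, none or still open, it means among the compounds named here.

In a functional assay on NCI-H460 cells (Homo sapiens) for cytotoxicity, read by MTT assay (a higher number here means a weaker inhibitor, a lower number a stronger inhibitor), compound 2, `Cc1nc(Nc2ccccc2)sc1C(=O)/C=C/c1ccc(Cl)cc1`, gives only a limit, > 25000 nM. Compound 1, `Cc1cccc(Nc2nc(C)c(C(=O)/C=C/c3ccccc3Cl)s2)c1`, likewise returns a limit in this assay, > 25000 nM. Both results share (the limit of > 25000 nM in this assay, at which 2 of the 2 values shown sit), so neither compound provides a number to compare. Compound 3, `Cc1nc(Nc2cccc(Cl)c2)sc1C(=O)/C=C/c1ccc(Cl)cc1`, differs from compound 2 by chloro in place of hydrogen on an aromatic carbon. Going by the values given here, no measured step exists here, so no change beyond the usual scatter is expected, and compound 3 will most likely again return only a limit in this assay. The expected step is a step that the limit leaves unreadable from compound 2 to compound 3. Compound 3 is estimated at 30000 nM, within 8000 nM to 120000 nM.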

Compound 3, half-maximal inhibitory concentration: > 25000 nM
Compound 3 was reported as a limit; the forecaster's own chance of this, stated with the estimate: 75%; the middle value is on the limit's open side.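

No step can be read from compound 2 to compound 3, because both give only a limit: the limit of > 25000 nM in this assay, at which 3 of the 3 values shown sit.

What chloro in place of hydrogen on an aromatic carbon does in this assay stays open, with no compound shown giving a number there.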